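This account rests on a few compounds, and the source may have more. Where it says the series, first, only, none or still open, it means among the compounds named here.

Measured so far:
compound 1 `Brc1cc(N2CC[C@H]3CN[C@H]3C2)cnc1Br` gives 7.8 nM;
compound 2 `N#Cc1cncc(N2CC[C@H]3CN[C@H]3C2)c1` gives 1900 nM;
compound 3 `COc1cc(N2CC[C@H]3CN[C@H]3C2)cnc1Br` gives 21 nM.

All three numbers come from a functional assay on HEK293 cells for agonist activity at Neuronal acetylcholine receptor; alpha4/beta2 (Homo sapiens), read by FLIPR; a higher number here means that more compound is needed for the effect, a lower number that less compound is needed. Compound 3 stands second highest of the three; its nearest neighbour is compound 1 and its furthest is compound 2. Going by the values given here, the only step that turns on a single change is a 2.7-fold higher number from compound 1 to compound 3 (0.43 log units; beyond the scatter), a modest rise. Compound 4 `N#Cc1cc(N2CC[C@H]3CN[C@H]3C2)cnc1Br` differs from compound 3 by cyano in place of methoxy on an aromatic carbon. Among the compounds with values here, no measured step swaps methoxy for cyano while the bromo group stays in place. Compound 2 carries a cyano group on a core without bromo and gives a far higher number, but it differs from compound 4 in more than one place, so its value is only a weak guide. For compound 4 a modest rise is therefore expected, a 1.7-fold higher number from compound 3 to compound 4 (0.22 log units; within the scatter). Compound 4 is estimated at 35 nM, within a range from 8 nM to 150 nM.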

Compound 4, half-maximal effective concentration: 6.1 nM
Compound 4: the middle estimate sits 5.7-fold (0.76 log units) above what was measured; the measured number lies below the stated range.
By their numbers in this assay, from the lowest: compounds 4 and 1 (each within the scatter of the next); then compound 3; then compound 2.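

In this assay cyano at this position, ortho to a bromo group, matches bromo (a 1.3-fold lower number from compound 1 to compound 4 (0.11 log units; within the scatter)) and beats methoxy (a 3.4-fold lower number from compound 3 to compound 4 (0.54 log units; beyond the scatter)). The bromo group on the ring carries far more weight (a 310-fold lower number from compound 2 to compound 4 (2.49 log units; beyond the scatter)), so the high number of compound 2 goes with the missing bromo and not with the cyano group. Nothing here gives a measured reason for these differences. Going by these compounds, whether an amine or a carboxylic acid at this position would match cyano stays open. Also open, on these data alone, is whether the bromo step stays this large with methoxy in place of cyano.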